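The compounds below may be only part of what the source reports. "The series", "measured", "known", "first", "only" and "open" are said of these compounds alone.

Measured in a physicochemical assay for solubility, read by HPLC, using the shake flask method, in phosphate buffer, with a stated time of 20 h, at pH 6.5; on this read-out lower numbers stand for lower solubility and higher numbers for higher solubility:
- compound 1 `O=C1CN(c2nccc3[nH]c(-c4ccc(F)c(F)c4)nc23)CCN1`: < 5000 nM (a limit, not a number)
- compound 2 `Fc1ccc(-c2nc3c(N4CCNCC4)nccc3[nH]2)cc1F`: 150000 nM
- compound 3 `C[C@@H]1CN(c2nccc3[nH]c(-c4ccc(F)c(F)c4)nc23)C[C@H](C)N1`: 190000 nM

Compound 3 and compound 2 form the upper pair, within the scatter of each other. Next comes compound 4 `C[C@@H]1CN(c2nccc3[nH]c(-c4ccc(F)c(F)c4)nc23)C[C@H](C)N1C`, with methyl in place of hydrogen on an amine nitrogen in a ring. Among the compounds with values here, no measured step makes this exact change. The closest is a 1.3-fold higher number from compound 2 to compound 3 (0.10 log units; within the scatter), with 3,5-dimethylpiperazin-1-yl in place of piperazin-1-yl. The large steps of an at least 30-fold higher number from compound 1 to compound 2 (1.47 log units; beyond the scatter) and an at least 38-fold higher number from compound 1 to compound 3 (1.57 log units; beyond the scatter) replace 3-oxopiperazin-1-yl, a different change, and bear on it less. The estimated 1.3-fold lower number from compound 3 to compound 4 (0.10 log units; within the scatter) is therefore expected to stay within the scatter in this assay. Compound 4 is expected at 150000 nM, with an estimated range from 60000 nM to 350000 nM.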

Compound 4, solubility: 50000 nM
Beside the measured number, compound 4's estimate is 3.0-fold (0.48 log units) above it; the measured number lies below the stated range.
By their numbers in this assay, from the lowest: compound 4; then compounds 2 and 3 (each within the scatter of the next). At a limit, below all of these: compound 1.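

In this assay methyl in place of hydrogen on the amine nitrogen in the ring gives a 3.8-fold lower number from compound 3 to compound 4 (0.58 log units; beyond the scatter), whereas adding the two ring methyl groups gave a 1.3-fold higher number from compound 2 to compound 3 (0.10 log units; within the scatter). This nitrogen is therefore a place where one added carbon moves the number beyond the scatter, though only modestly, with no change to the 3-oxopiperazin-1-yl position involved. Nothing measured here accounts for this step.

From the compounds shown here alone, whether ethyl or acetyl on this nitrogen would move the number further stays open. So does whether the step needs the two ring methyl groups, as methyl on the piperazin-1-yl nitrogen of compound 2 would show.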